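Dropping the Chloro Group: An Expected Lipophilicity Step

A few compounds are considered here, and "the series" means these few. Any claim that something is new, unique, unknown or untested is made for them only; others in the source may bear on it.

Measured compounds:
compound 1, `O=C(COc1cccc2ccccc12)N/N=C/c1cccc([N+](=O)[O-])c1`, 3.97
compound 2, `O=C(COc1cccc2ccccc12)N/N=C/c1ccccc1Cl`, 4.54

In a physicochemical assay for lipophilicity, measured as octanol-water partition (on this read-out higher numbers stand for higher lipophilicity and lower numbers for lower lipophilicity), compound 1 gives 3.97, while compound 2 gives 4.54. Going by the values given here, compound 2 therefore stands highest of the two numbers known so far; its only neighbour, compound 1, sits lower by a margin beyond the scatter. Among the compounds with values here, no single-point step between these two has been worked out, so their two values show only that compound 2 is the more lipophilic of the pair.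

Compound 3, `O=C(COc1cccc2ccccc12)N/N=C/c1ccccc1`, has not yet been measured in this assay. Against compound 2 it differs in one place:

hydrogen in place of chloro on an aromatic carbon

Within the data shown here, no measured pair in this set mirrors that change, so the size of the step rests on the change itself rather than on a recorded analogue. The expectation is a clear fall in this assay, beyond the scatter, with the expected step being a number 0.69 log units lower from compound 2 to compound 3 (beyond the scatter). Compound 3 is accordingly estimated at 3.85, with a range from 3.5 to 4.2.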

Compound 3, partition coefficient: 4.02
Compound 3: middle estimate off by 0.17 log units, on the low side, and the stated range covers the measured number.
By their numbers in this assay, from the lowest: compounds 1 and 3 (each within the scatter of the next); then compound 2.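

The 2-chlorophenyl to phenyl change gives this series its first single-place step: in this assay, hydrogen in place of chloro on an aromatic carbon, ortho to a large group, gives a number 0.52 log units lower from compound 2 to compound 3 (beyond the scatter) and so shows that the chloro at this place makes a difference that can be read on this scale. Compound 3 also ties compound 1 into a direct comparison, since taking away the nitro group and leaving a hydrogen gives a number 0.05 log units higher from compound 1 to compound 3 (within the scatter) and leaves that pair indistinguishable on this read-out. The data offer no measured explanation for either step.

Going by these compounds alone, these two steps show only two exchanges on the shared core, so they leave open whether fluoro, bromo, methyl, methoxy, an amine or a carboxylic acid at the chloro's place would give a step of similar size in this assay or a different one. They also leave open whether chloro on another carbon of the same ring would give the step seen here, and whether the step would hold on a different core.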